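A few compounds are considered here, and "the series" means these few. Any claim that something is new, unique, unknown or untested is made for them only; others in the source may bear on it.

Measured compounds:
- compound 1 `O=c1ccc(-c2ccccc2)nn1CCCCNC(=S)NC1CCCCC1` gives 18.1% in a functional assay on the whole organism with Rattus norvegicus as the target, at a dose of 100 mg/kg; a lower number here means less inhibition, a higher number more inhibition at the dose given (going by the name of the read-out)
- compound 2 `CC(C)(C)/N=C(\S)NCCCCn1nc(-c2ccccc2)ccc1=O` gives 33.6% in this assay
- compound 3 `O=c1ccc(-c2ccccc2)nn1CCCCNC(=S)Nc1ccccc1` gives 38.4% in this assay

Compound 3 stands highest of the three numbers, though its margin over compound 2 is within the scatter (a number 4.8 percentage points higher from compound 2 to compound 3 (within the scatter)), so the two cannot be ordered; only compound 1 lies clearly lower (a number 20.3 percentage points higher from compound 1 to compound 3 (beyond the scatter)).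

Compound 4 `CCC/N=C(/NC#N)NCCCCn1nc(-c2ccccc2)ccc1=O` is not yet measured. It differs from compound 3 in one place: a group of 8 heavy atoms (5 carbon, 3 nitrogen; no ring) in place of a group of 9 heavy atoms (7 carbon, 1 nitrogen, 1 sulfur; one six-membered aromatic ring of carbon only), on an amine nitrogen. For the measured compounds named here, two measured steps bear on this position. Replacing the cyclohexyl by phenyl gave a number 20.3 percentage points higher from compound 1 to compound 3 (beyond the scatter), and replacing it by the ring-free group gave a number 15.5 percentage points higher from compound 1 to compound 2 (beyond the scatter); the aromatic and the ring-free groups sit within the scatter of each other (a number 4.8 percentage points higher from compound 2 to compound 3 (within the scatter)). Going by the values given here, the group entering in compound 4 carries no ring and replaces the sulfur by nitrogen and a nitrile; no measured pair tests that exchange. The ring-free precedent of compound 2 (33.6%) suggests a modest drop or none beyond the scatter rather than a rise.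

For compound 4 the expected step is a number 8.4 percentage points lower from compound 3 to compound 4 (within the scatter), within the scatter. Compound 4 is estimated at 30%, with a range from 10% to 50%, the width reflecting the untested sulfur-to-nitrile change.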

Compound 4, a percentage reported as inhibition, in the whole organism at one dose (the size of the read-out at that dose, not a potency): 26.3%
Compound 4: middle estimate off by 3.7 percentage points, on the high side, and the stated range covers the measured number.
By their numbers in this assay, from the lowest: compounds 1, 4, 2 and 3 (each within the scatter of the next, the first and the last beyond it).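

In this assay, for the compounds shown here, the group with the nitrile is the first at this position to carry no sulfur, and it can be read clearly against only one of the sulfur-bearing groups: a number 12.1 percentage points lower from compound 3 to compound 4 (beyond the scatter). Against the other two the exchange does not separate, with a number 7.3 percentage points lower from compound 2 to compound 4 (within the scatter) for the ring-free group and a number 8.2 percentage points higher from compound 1 to compound 4 (within the scatter) for the cyclohexyl-bearing group, so the new group cannot be placed apart from either of them and only the phenyl-bearing group of compound 3 stands clearly off from it. No measurement on hand accounts for any of these steps.

No pair shown isolates the sulfur-to-nitrile exchange from the other differences in the group, so it stays open whether a phenyl or a cyclohexyl on the nitrile-bearing group would follow the order seen among compound 1, compound 2 and compound 3. Also open are how a urea carbonyl in place of the sulfur or a shorter or longer chain to the shared core would read, and how any of these compounds would respond at another dose, as a single dose gives no potency.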